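The source may report more compounds than this note shows. Statements on the series, on what has been measured and on what is new or still open speak of the compounds shown alone.

Of the compounds shown here, three that share one core have been measured in an assay on IMR-32 cells for displacement of a labelled ligand from corticotropin-releasing factor receptor 1 (Homo sapiens), read by scintillation counting, with a stated time of 2 h; a higher number here means a weaker inhibitor, a lower number a stronger inhibitor. Compound 1 `CCc1nc(-c2ccc(Cl)cc2Cl)c(CC)nc1NC(COC)COC` gives 224 nM. Compound 2 `CCc1nc(N(CC2CC2)CC2CC2)c(CC)nc1-c1ccc(Cl)cc1Cl` gives 26 nM. Compound 3 `CCc1nc(-c2ccc(Cl)cc2Cl)c(CC)nc1NC(C)CN(C)C` gives 489 nM, the highest of the three numbers and therefore the weakest binding seen so far; two steps fix its position: a 2.2-fold higher number from compound 1 to compound 3 (0.34 log units; beyond the scatter), and a 19-fold higher number from compound 2 to compound 3 (1.27 log units; beyond the scatter).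

Compound 4 `CCCN(CCN(C)C)c1nc(CC)c(-c2ccc(Cl)cc2Cl)nc1CC` has not yet been measured. It differs from compound 3 in one place: (2-(dimethylamino)ethyl)(propyl)amino in place of (1-((dimethylamino)methyl)ethyl)amino on an aromatic carbon. The one hydrogen-bond donor of the leaving group is gone, while the two hydrogen-bond acceptors remain.

One measured step makes a comparable trade, from an amino group with a hydrogen-bond donor to one without: an 8.6-fold lower number from compound 1 to compound 2 (0.94 log units; beyond the scatter). Its mirror, a 19-fold higher number from compound 2 to compound 3 (1.27 log units; beyond the scatter), is large. Both point the same way, towards a lower number when the donor is removed. Compound 4, however, does not carry the bis(cyclopropylmethyl) pair of compound 2, and it keeps the dimethylamino chain of compound 3, so a smaller shift is expected than either step. The expected change is a 4.1-fold lower number from compound 3 to compound 4 (0.61 log units; beyond the scatter), a modest lowering. For compound 4 the estimate in this assay is 120 nM, with a range from 35 nM to 400 nM.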

Compound 4, inhibition constant: 1540 nM
Estimate against measurement, compound 4: 13-fold (1.11 log units) below; measured number outside the range, above it.
By their numbers in this assay, from the lowest: compound 2; then compound 1; then compound 3; then compound 4.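

In this assay, removing the one hydrogen-bond donor of the leaving group while keeping its two acceptors did not lower the number at this position on the aromatic carbon: the result was a 3.1-fold higher number from compound 3 to compound 4 (0.50 log units; beyond the scatter). Compound 4 therefore goes against the direction seen when compound 2 was compared with compound 1 and compound 3, and its amino group also has no donor, yet the gap to the bis(cyclopropylmethyl)amino compound is a 59-fold higher number from compound 2 to compound 4 (1.77 log units; beyond the scatter); lacking a donor is clearly not enough on its own to give a low number. The new group also falls behind the (2-methoxy-1-(methoxymethyl)ethyl)amino group, as shown by a 6.9-fold higher number from compound 1 to compound 4 (0.84 log units; beyond the scatter), so what is attached to this nitrogen matters beyond the donor count.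

No measurement here accounts for the rise in the number. The change from compound 3 to compound 4 alters the chain and adds a propyl group in one step, so their separate contributions remain unresolved, as does whether a butyl chain in place of the propyl would raise or lower the number.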